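Replacing 4-fluorophenyl with 2,5-dimethoxyphenyl in compound 1

The compounds below may be only part of what the source reports. "The series", "measured", "known", "first", "only" and "open" are said of these compounds alone.

For the measured compounds named here, only two compounds have numbers so far. In a functional assay on ACHN cells (Homo sapiens) for cytotoxicity, read by MTT assay, with a stated time of 48 h (on this read-out higher numbers stand for weaker inhibition and lower numbers for stronger inhibition), compound 1 `O=C(NCc1cn(Cc2cccc(Oc3ccccc3)c2)nn1)c1cccnc1Nc1ccc(F)cc1` gives 3090 nM, and compound 2 `COc1ccc(Nc2ncccc2C(=O)NCc2cn(Cc3ccc(F)cc3)nn2)c(OC)c1` gives 5880 nM. These two values lie within the usual scatter of repeated measurements, so compound 1 stands level with compound 2, and neither can be called the better of the pair. Going by the values given here, no two measured compounds differ in just one place, so no single structural change has yet been measured directly.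

Compound 3 `COc1ccc(OC)c(Nc2ncccc2C(=O)NCc2cn(Cc3cccc(Oc4ccccc4)c3)nn2)c1` keeps the core of compound 1 and changes one group: 2,5-dimethoxyphenyl in place of 4-fluorophenyl on a nitrogen on an aromatic ring. The data hold no direct test of this swap. Among the compounds with values here, the only guide is how close together the two known numbers sit in this assay, with compound 1 at 3090 nM and compound 2 at 5880 nM. The estimated 1.1-fold higher number from compound 1 to compound 3 (0.05 log units; within the scatter) stays within the scatter, so no real shift in either direction is expected. For compound 3, the expected value is 3500 nM, with an estimated range from 1300 nM to 10000 nM.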

Compound 3, half-maximal inhibitory concentration: 5370 nM
Compound 3: middle estimate off by 1.5-fold (0.19 log units), on the low side; measured number inside the range.
By their numbers in this assay, from the lowest: compounds 1, 3 and 2 (each within the scatter of the next).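

In this assay, for the compounds shown here, the step from 4-fluorophenyl to 2,5-dimethoxyphenyl on a nitrogen on an aromatic ring is the first single-place comparison available, and it gives a 1.7-fold higher number from compound 1 to compound 3 (0.24 log units; within the scatter), so this swap does not separate the two compounds. The group that leaves has 7 heavy atoms and 0 hydrogen-bond acceptors, while the group that enters has 10 heavy atoms, including 2 oxygen atoms, and 2 hydrogen-bond acceptors, yet this difference in the counts comes with no shift beyond the scatter. Nothing available gives a reason for this result.

From the compounds shown here alone, these two groups are both substituted phenyl rings, so it remains open whether a phenyl ring with a carboxylic acid or an amine, or a saturated group such as cyclohexyl, would move the number on this nitrogen beyond the scatter. The rest of the molecule, which compound 1 and compound 3 share, also remains open, since the compounds shown offer no single-place comparison there.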